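The source may report more compounds than this note shows. Statements on the series, on what has been measured and on what is new or still open speak of the compounds shown alone.

Measured compounds:

compound 1, `CCOC(=O)c1cc2ccc(OCCCn3cc(CNC(=O)CCCCC4CCSS4)nn3)cc2oc1=O` — 36.1%
compound 2, `O=C(CCCCC1CCSS1)NCc1cn(CCCOc2ccc3cc(-c4ccccc4)c(=O)oc3c2)nn1` — 29.1%
compound 3, `CCOC(=O)c1cc2ccc(OCCCCCn3cc(CNC(=O)CCCCC4CCSS4)nn3)cc2oc1=O` — 38.3%

Of the compounds shown here, three have been measured in a functional assay on PC-12 cells (Rattus norvegicus) for cytotoxicity, read by MTT assay, with stated times of 3 h and 2 h, tested at 10 uM; on this read-out higher numbers stand for a stronger effect at the one concentration tested and lower numbers for a weaker effect. In this assay compound 1 gives 36.1%, compound 2 gives 29.1% and compound 3 gives 38.3%. Each compound carries a dithiolane-containing amide chain linked through a triazole to a coumarin-like core, and they differ in what sits on that core and in the length of the linking chain.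

Compound 1 and compound 2 differ in one place only: phenyl in place of ethoxycarbonyl on an aromatic carbon. This single change made a number 7 percentage points lower from compound 1 to compound 2 (within the scatter). Compound 3 and compound 1 differ in the linking chain; the difference between these two cores is not broken down here, and their two values lie close together.

Compound 4, `O=C(CCCCC1CCSS1)NCc1cn(CCCCCOc2ccc3cc(-c4ccccc4)c(=O)oc3c2)nn1`, has not yet been measured. It stands to compound 3 as compound 2 stands to compound 1, and the change is described in the same way: phenyl in place of ethoxycarbonyl on an aromatic carbon. The surroundings of the place of change read identically in both pairs, so this is the same change made on a core with the longer chain.

The step from compound 3 to compound 4 is expected to be a number 7.3 percentage points lower from compound 3 to compound 4 (within the scatter), set beside the measured step because the same change gave a number 7 percentage points lower from compound 1 to compound 2 (within the scatter). On that basis compound 4 is estimated to give 31% in this assay, with a likely range from 22% to 40%.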

Compound 4, a percentage reported as activity, at one concentration (the size of the read-out at that concentration, not a potency): 26.3%
The estimate for compound 4 lay 4.7 percentage points above the measured number; measured number inside the range.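

In this assay, putting phenyl in place of ethoxycarbonyl on the core of compound 3 gave a number 12 percentage points lower from compound 3 to compound 4 (beyond the scatter). Set beside the earlier step, the change carries across the two cores, which differ in the linking chain, and the two steps cannot be told apart in size: the same change on two cores in this assay, a number 7 percentage points lower (within the scatter) from compound 1 to compound 2 and a number 12 percentage points lower (beyond the scatter) from compound 3 to compound 4, 5 percentage points apart, within the scatter of two such steps This supports treating the swap as a step of similar size on these two cores, but it does not show that the step truly grows with the linking chain, why the number moves, or whether the same would hold on a core that differs in some other way.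

The compounds shown leave open what other groups at this aromatic carbon would do, such as an amine or a carboxylic acid in place of the phenyl or ethoxycarbonyl, and whether a still longer chain than the one in compound 3 and compound 4 would leave the step unchanged. With one concentration tested, each number gives only the size of the effect at that concentration, and the compounds shown also leave open how the effects would compare at other concentrations.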